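Cyclohexyl in place of pentan-3-yl in compound 4

The compounds below may be only part of what the source reports. "The series", "measured", "known", "first", "only" and "open" are said of these compounds alone.

In a functional assay on MCF7 cells (Homo sapiens) for inhibition, read by XTT assay, with a stated time of 48 h (a lower number here means a stronger inhibitor, a higher number a weaker inhibitor), compound 3 `CCC(/C=C(\CCOC(C)=O)C(=O)c1ccc(OC)cc1)CC` gives only a limit of the assay, > 100000 nM. Compound 2 `COc1ccc(C(=O)/C(=C/c2ccccc2F)CCOC(C)=O)cc1` likewise gives only a limit in this assay, > 100000 nM. The step that the two limits leave unreadable from compound 2 to compound 3 is therefore of unreadable size, since both of its ends sit at the limit of > 100000 nM in this assay, at which 2 of the 3 values shown sit. Compound 1 `COc1ccc(C(=O)/C(=C/C2CCCCC2)COC(C)=O)cc1` differs from compound 3 in several places at once; in this assay compound 1 gives 24000 nM.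

Compound 4 `COc1ccc(C(=O)/C(=C/C2CCCCC2)CCOC(C)=O)cc1` differs from compound 3 by cyclohexyl in place of pentan-3-yl on a double-bonded chain carbon bound to a double-bonded chain carbon. Going by the values given here, no measured step pairs a cyclohexyl compound with a pentan-3-yl one, and the only measured step that touches compound 3 carries no readable size. Compound 1, which also bears cyclohexyl, shows that this group can sit beside a number inside the range of this assay. Compound 4 is therefore expected to move off the limit toward a weak but measurable value, an at least 1.6-fold lower number from compound 3 to compound 4 (0.22 log units; that floor lies within the scatter). The estimate for compound 4 is 60000 nM, within 15000 nM to 200000 nM, with a fair chance that this assay again reports only a limit.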

Compound 4, half-maximal inhibitory concentration: > 100000 nM
Compound 4: a limit, no number; the forecaster's own chance of this, stated with the estimate: 50%; middle value at least 1.6-fold (0.22 log units) away from the limit.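

In this assay, acetoxymethyl in place of acetoxy on a saturated chain carbon bound to a double-bonded chain carbon gives an at least 4.1-fold higher number from compound 1 to compound 4 (0.61 log units; beyond the scatter) with cyclohexyl present in both compounds, so the measurable value of compound 1 does not carry over to the acetoxymethyl compounds. The steps among compound 2, compound 3 and compound 4 cannot be read, and cyclohexyl, pentan-3-yl and 2-fluorophenyl cannot be ranked at the double-bonded chain carbon. With acetoxymethyl, none of these groups gives a number: the limit of > 100000 nM in this assay, at which 3 of the 4 values shown sit.

The compounds shown leave open whether pentan-3-yl or 2-fluorophenyl would give a measurable value alongside acetoxy, as cyclohexyl does in compound 1. They also leave open how an amine or a carboxylic acid in place of acetoxy would read in this assay.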